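The source may report more compounds than this note shows. Statements on the series, on what has been measured and on what is new or still open speak of the compounds shown alone.

In an ADME assay on microsomes from liver (Homo sapiens) for metabolic stability, read by LC-MS, tested at 1 uM (a higher number here means faster removal of the compound, a lower number slower removal), compound 1 `c1cc([C@H]2CC[C@]3(CC2)OOC2(O3)C3CC4CC(C3)CC2C4)ccc1OCCCNC1CCOCC1` gives 10 mL.min-1.g-1. Going by these compounds, compound 2 `CC(C)(N)CCOc1ccc([C@H]2CC[C@]3(CC2)OOC2(O3)C3CC4CC(C3)CC2C4)cc1` gives < 7 mL.min-1.g-1, which is a limit of the assay and not a number, so its exact standing remains unknown. Compound 3 `c1cc([C@H]2CC[C@]3(CC2)OOC2(O3)C3CC4CC(C3)CC2C4)ccc1OCCC1CCNCC1` differs from compound 2 by piperidin-4-yl in place of 1-amino-1-methylethyl on a saturated chain carbon, two bonds along the chain from an oxygen on an aromatic ring, with piperidin-4-yl in place of 1-amino-1-methylethyl on a saturated chain carbon, two bonds along the chain from an oxygen on an aromatic ring. Among the compounds with values here, the one measured step at this place is an at least 1.4-fold lower number from compound 1 to compound 2 (0.15 log units; that floor lies within the scatter). It does not involve piperidin-4-yl, so it is only a loose guide. On the strength of that step, no change beyond the scatter is expected in this assay, and no direction can be favoured. For compound 3 the estimated value is 7 mL.min-1.g-1, with an expected range of 3.5 mL.min-1.g-1 to 14 mL.min-1.g-1. The expected step is a number no lower from compound 2 to compound 3 (the limit leaves the size open).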

Compound 3, intrinsic clearance in microsomes: < 7 mL.min-1.g-1
Compound 3 was reported as a limit; the forecaster's own chance of this, stated with the estimate: 40%; the middle value lies on the limit itself.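

In this assay compound 3 gives < 7 mL.min-1.g-1, which is a limit of the assay and not a number. Within the data shown here, the step between compound 2 and compound 3 cannot be read, and the one readable step is an at least 1.4-fold lower number from compound 1 to compound 3 (0.15 log units; that floor lies within the scatter). What is new is that a group with a six-membered non-aromatic ring, piperidin-4-yl, on a saturated chain carbon, two bonds along the chain from an oxygen on an aromatic ring, ends at the same limit as the open-chain 1-amino-1-methylethyl: the limit of < 7 mL.min-1.g-1 in this assay, at which 2 of the 3 values shown sit.

Going by these compounds, the true values of compound 2 and compound 3 remain unknown, so these two groups cannot be ranked in this assay. On these data alone, it also remains open whether a carboxylic acid, a morpholine or a longer chain at this place would stay at that limit.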